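Urea aryl variation on a shared thienopyrimidine-type series

This account rests on a few compounds, and the source may have more. Where it says the series, first, only, none or still open, it means among the compounds named here.

Compound 1 `CCN(CC)CCCNc1nc(-c2ccc(NC(=O)Nc3ccc(F)cc3)cc2)nc2ccsc12` and compound 2 `CCN(CC)CCCNc1nc(-c2ccc(NC(=O)Nc3ccccc3F)cc2)nc2ccsc12` share one core and differ only in the fluorophenyl attached to the urea nitrogen. In a functional assay on MKN-45 cells (Homo sapiens) for cytotoxicity, read by MTT assay, with a stated time of 72 h (on this read-out higher numbers stand for weaker inhibition and lower numbers for stronger inhibition), compound 1 gives 470 nM, and compound 2 gives 580 nM. The step of a 1.2-fold higher number from compound 1 to compound 2 (0.09 log units; within the scatter) is within the scatter, so the two numbers cannot be told apart; compound 2 simply carries the numerically larger of the two read-outs measured so far.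

Compound 3 `CCN(CC)CCCNc1nc(-c2ccc(NC(=O)Nc3ccc(C)cc3)cc2)nc2ccsc12` is not yet measured. Its difference from compound 2 is 4-methylphenyl in place of 2-fluorophenyl on an amide-type nitrogen. Within the data shown here, the only measured step that bears on this place is a 1.2-fold higher number from compound 1 to compound 2 (0.09 log units; within the scatter), which moved a fluorine between two positions of the same ring without a change beyond the scatter. Among the measured compounds shown here, no measured compound carries a methyl on this ring, so the effect of the 4-methylphenyl itself is unknown here. The expectation is therefore a step of about a 1.1-fold lower number from compound 2 to compound 3 (0.05 log units; within the scatter) in this assay, with no direction claimed beyond the scatter. For compound 3 the estimated value is 520 nM, expected to fall between 200 nM and 1400 nM.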

Compound 3, half-maximal inhibitory concentration: 1760 nM
The estimate for compound 3 lay 3.4-fold (0.53 log units) below the measured number; measured number outside the range, above it.
By their numbers in this assay, from the lowest: compounds 1 and 2 (each within the scatter of the next); then compound 3.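

Fluorine on this urea aryl ring had so far given no reading beyond the scatter, but the ring is not indifferent to every substituent: in this assay, exchanging fluoro for methyl on the aromatic carbon gives a 3.7-fold higher number from compound 1 to compound 3 (0.57 log units; beyond the scatter). The comparison with the other fluorinated compound points the same way, with a 3.0-fold higher number from compound 2 to compound 3 (0.48 log units; beyond the scatter), although this step changes both the substituent and its location on the ring, so the cleaner reading of the methyl-for-fluoro exchange comes from the first step. Across these three compounds, both fluorophenyl ureas therefore give lower numbers than the 4-methylphenyl urea, and no measurement here accounts for that difference.

The compounds shown leave open whether the higher number reflects the loss of fluorine or the arrival of methyl, a question that a plain phenyl group on the same urea nitrogen would help to separate. They also leave open how far the trend extends to other groups on this ring, such as chloro or methoxy, and whether the methyl exchange would read the same way in a different cell line.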